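A few compounds are considered here, and "the series" means these few. Any claim that something is new, unique, unknown or untested is made for them only; others in the source may bear on it.

Measured so far in a functional assay on HeLa cells (Homo sapiens) for antiproliferative activity, read by MTT assay, with a stated time of 48 h; on this read-out lower numbers stand for stronger inhibition and higher numbers for weaker inhibition:
- compound 1 `COc1ccc2nc(NC(c3cn(-c4ccccc4)nc3-c3cccc([N+](=O)[O-])c3)c3c(O)ccc4ccccc34)sc2c1` gives 6140 nM
- compound 2 `O=[N+]([O-])c1cccc(-c2nn(-c3ccccc3)cc2C(Nc2nc3ccc(Cl)cc3s2)c2c(O)ccc3ccccc23)c1` gives 15500 nM

Compound 2 holds the higher of the two numbers. Next comes compound 3 `Oc1ccc2ccccc2c1C(Nc1nc2ccc(Cl)cc2s1)c1cn(-c2ccccc2)nc1-c1ccccc1` with hydrogen in place of nitro on an aromatic carbon. For the measured compounds named here, the only measured step, a 2.5-fold higher number from compound 1 to compound 2 (0.40 log units; beyond the scatter), is a chloro in place of methoxy change elsewhere in the molecule, and no measured step touches the nitro. Going by the values given here, that modest step is the sole guide to size, so no shift beyond the scatter is expected in this assay, and the direction remains open. The estimated outcome is a 1.3-fold lower number from compound 2 to compound 3 (0.11 log units; within the scatter) as a best guess. For compound 3 the expected value is 12000 nM (3500 nM to 40000 nM) on present data.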

Compound 3, half-maximal inhibitory concentration: 12500 nM
The estimate for compound 3 lay 1.0-fold (0.02 log units) below the measured number, and the stated range covers the measured number.
By their numbers in this assay, from the lowest: compound 1; then compounds 3 and 2 (each within the scatter of the next).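

In this assay, going from 3-nitrophenyl to phenyl gives a 1.2-fold lower number from compound 2 to compound 3 (0.09 log units; within the scatter) and so stays within the scatter: with the chloro compounds, this place on the ring tolerates loss of the nitro without a resolved shift. For the compounds shown here, the only step beyond the scatter remains the chloro in place of methoxy change, a 2.5-fold higher number from compound 1 to compound 2 (0.40 log units; beyond the scatter) on the other side of the molecule. Nothing at hand explains the flat nitro step.

On these data alone, whether the same flatness holds with methoxy in place of chloro remains open. Also open, as far as these compounds go, is whether an amine or a carboxylic acid at this place would shift the number beyond the scatter.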